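Bromo for Chloro on Two Related Cores

A few compounds are considered here, and "the series" means these few. Any claim that something is new, unique, unknown or untested is made for them only; others in the source may bear on it.

Three compounds were measured in a functional assay on MV4-11 cells (Homo sapiens) for cytotoxicity, read by MTT assay, with a stated time of 72 h; on this read-out higher numbers stand for weaker inhibition and lower numbers for stronger inhibition:

compound 1, `CC(C)(C)c1cc(NC(=O)Nc2ccc(-c3cn4ccc(Cl)cc4n3)cc2)no1`: 5.91 nM
compound 2, `CC(C)(C)c1cc(NC(=O)Nc2ccc(-c3cn4ccc(Br)cc4n3)cc2)no1`: 9.59 nM
compound 3, `CC(C)(C)c1cc(NC(=O)Nc2ccc(-c3cn4cc(Cl)ccc4n3)cc2)no1`: 24.8 nM

Compound 1 and compound 3 are built from the same atoms joined differently; the difference between the two cores is not broken down here. What the values show is that compound 3 stands highest of the three, and its gap to compound 1 and to compound 2 lies beyond the usual scatter.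

Compound 2 differs from compound 1 by bromo in place of chloro on an aromatic carbon. This change produced a 1.6-fold higher number from compound 1 to compound 2 (0.21 log units; within the scatter).

The unmeasured compound 4, `CC(C)(C)c1cc(NC(=O)Nc2ccc(-c3cn4cc(Br)ccc4n3)cc2)no1`, differs from compound 3 by bromo in place of chloro on an aromatic carbon. The group that leaves and the group that enters are the same as in the change from compound 1 to compound 2, and the place is again on an aromatic carbon of a six-membered aromatic ring with one nitrogen within a fused system of two rings, meta and para to a fused ring. The surroundings differ, though: in compound 1 the carbon is opposite the ring nitrogen, whereas in compound 3 it is two atoms from the ring nitrogen. The two changes are therefore the same kind of change, not the same.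

Because the earlier change gave a 1.6-fold higher number from compound 1 to compound 2 (0.21 log units; within the scatter), the step from compound 3 to compound 4 is expected to be of similar size, a 1.6-fold higher number from compound 3 to compound 4 (0.21 log units; within the scatter), with wider uncertainty since the cores differ. Compound 4 is estimated to give 40 nM in this assay, expected to fall between 15 nM and 110 nM.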

Compound 4, half-maximal inhibitory concentration: 44.5 nM
Compound 4: the middle estimate sits 1.1-fold (0.05 log units) below what was measured, within the range that was stated.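

In this assay, bromo in place of chloro on an aromatic carbon gave a 1.8-fold higher number from compound 3 to compound 4 (0.25 log units; within the scatter), so on the core of compound 3, with the halogen two atoms from the ring nitrogen, the change again stayed within the usual scatter. Set beside the earlier step, the change carried from one core to the other with much the same size: the same change on two cores in this assay, a 1.6-fold higher number (0.21 log units; within the scatter) from compound 1 to compound 2 and a 1.8-fold higher number (0.25 log units; within the scatter) from compound 3 to compound 4, 1.1-fold (0.04 log units) apart, within the scatter of two such steps. Both steps lie within the scatter, which leaves bromo and chloro unranked on either core, and this single pair of cores gives no reading of how the change would behave on a third core or in any other assay.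

The compounds shown leave open what groups other than the two halogens would do at these places on either core, for instance fluoro, methoxy, nitrile, an amine or a carboxylic acid. They also leave open whether a hydrogen at the same carbon would give a value apart from those of the halogens, and whether a longer chain in place of the tert-butyl group would keep the values of this series.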